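Methoxy on the piperazine aryl ring: compound 4 before measurement

The source may hold more compounds than are shown below. What is called first, only, known or untested is meant among the compounds shown, and "the series" means these compounds.

Measured so far in a functional assay on SW 1116 cells (Homo sapiens) for antiproliferative activity, read by MTT assay, with a stated time of 48 h; a higher number here means a weaker inhibitor, a lower number a stronger inhibitor:
Compound 1 `S=c1oc(-c2ccc3c(c2)OCCO3)nn1CN1CCN(c2cccc(Cl)c2Cl)CC1` gives 37100 nM.
Compound 2 `S=c1oc(-c2ccc3c(c2)OCCO3)nn1CN1CCN(c2cccc(Cl)c2)CC1` sits at a limit of this assay, > 50000 nM.
Compound 3 `S=c1oc(-c2ccc3c(c2)OCCO3)nn1CN1CCN(c2ccccc2)CC1` likewise sits at a limit of this assay, > 50000 nM.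

Compound 3 thus stands at the limit shared by two of the three values shown (the limit of > 50000 nM in this assay, at which 2 of the 3 values shown sit); only compound 1 gives a number. Compound 4 `COc1ccccc1N1CCN(Cn2nc(-c3ccc4c(c3)OCCO4)oc2=S)CC1` differs from compound 3 by methoxy in place of hydrogen on an aromatic carbon.

Of the measured steps, an at least 1.3-fold higher number from compound 1 to compound 3 (0.12 log units; that floor lies within the scatter) and a step that the two limits leave unreadable from compound 2 to compound 3 touch the same ring, both involving chloro rather than methoxy, and neither resolves a readable size. Among the measured compounds shown here, no step here shows methoxy entering. The expectation for compound 4 is therefore a step of about a number no higher from compound 3 to compound 4 (the limit leaves the size open), that is, no change beyond the scatter, with a substantial chance that this assay again reports only a limit. Compound 4 is estimated at 50000 nM, expected between 20000 nM and 120000 nM.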

Compound 4, half-maximal inhibitory concentration: 16900 nM
Compound 4: the middle estimate sits 3.0-fold (0.47 log units) above what was measured, outside the stated range (below it).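

In this assay, methoxy on this ring gives a readable gain over the unsubstituted phenyl: an at least 2.9-fold lower number from compound 3 to compound 4 (0.47 log units; beyond the scatter). The 2-methoxyphenyl group also outdoes both chlorinated rings, with an at least 2.9-fold lower number from compound 2 to compound 4 (0.47 log units; beyond the scatter) and a 2.2-fold lower number from compound 1 to compound 4 (0.34 log units; beyond the scatter), making compound 4 the strongest of the four. Compound 2 and compound 3 each give a limit rather than a number, so the first two steps are floors: the limit of > 50000 nM in this assay, at which 2 of the 4 values shown sit.

From the compounds shown here alone, how large the gain over phenyl really is remains open. So does whether an amine or a hydroxyl group in place of the methoxy would keep it.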